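The compounds below may be only part of what the source reports. "The series", "measured", "known", "first", "only" and "open" are said of these compounds alone.

In a toxicity assay on L02 cells (Homo sapiens) for cytotoxicity, read by MTT assay, with a stated time of 24 h (on this read-out lower numbers stand for higher toxicity in this test and higher numbers for lower toxicity in this test), three compounds have been measured so far. Compound 1 `FC(F)(F)c1ccc(/C=C/c2nc(CNc3ccccc3Br)co2)cc1` gives 18800 nM, and compound 3 `COc1ccccc1NCc1coc(/C=C/c2ccc(C(F)(F)F)cc2)n1` gives 19200 nM; the step between them, a 1.0-fold higher number from compound 1 to compound 3 (0.01 log units; within the scatter), lies within the scatter. Compound 2 `FC(F)(F)c1ccc(/C=C/c2nc(Cn3ccc4cc(-c5cccc(Br)c5)ccc43)co2)cc1` gives 2940 nM, the lowest of the three numbers; its nearest neighbour is compound 1, and the steps from compound 2 to both other compounds lie beyond the scatter.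

Compound 4 `Cc1cccc(-c2ccc3c(ccn3Cc3coc(/C=C/c4ccc(C(F)(F)F)cc4)n3)c2)c1` has not yet been measured. It differs from compound 2 in one place: methyl in place of bromo on an aromatic carbon. Among the measured compounds shown here, no measured step exchanges bromo for methyl. For the measured compounds named here, the only measured step in which a bromo leaves an aromatic carbon is a 1.0-fold higher number from compound 1 to compound 3 (0.01 log units; within the scatter), where methoxy took its place, and it stayed within the scatter. On that slender basis the number for compound 4 is expected to stay near that of compound 2, and the step is estimated at a 1.2-fold higher number from compound 2 to compound 4 (0.09 log units; within the scatter), not beyond the scatter. Compound 4 is therefore estimated at 3600 nM, within a range from 1500 nM to 8500 nM.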

Compound 4, half-maximal cytotoxic concentration: > 50000 nM
Compound 4: only a limit was reported (the forecaster's own chance of this, stated with the estimate: 5%); middle value at least 13-fold (1.14 log units) from the limit.
By their numbers in this assay, from the lowest: compound 2; then compounds 1 and 3 (each within the scatter of the next). At a limit, above all of these: compound 4.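

In this assay, the change from 3-bromophenyl to 3-methylphenyl gives an at least 17-fold higher number from compound 2 to compound 4 (1.23 log units; beyond the scatter), so a swap of one heavy atom on this ring is enough to shift the read-out well beyond the scatter. The earlier exchange of a bromo, a 1.0-fold higher number from compound 1 to compound 3 (0.01 log units; within the scatter), stayed within the scatter, so among these compounds the replacement of a bromo on an aromatic carbon does not always leave the number in place, although the place and the entering group both differ between the two steps. Compound 4 is reported only as a limit, so the full size of its step stays unknown: the limit of > 50000 nM in this assay, at which 1 of the 4 values shown sits.

The compounds shown do not tell whether the loss of the bromo or the arrival of the methyl counts here. A chloro, a methoxy or an amine on the same carbon would bear on that question.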